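Methoxy on the Benzyl Arm of an Inactive Urea

The source may report more compounds than this note shows. Statements on the series, on what has been measured and on what is new or still open speak of the compounds shown alone.

Measured compounds:
compound 1, `C#CCNC(=O)Nc1cccc(CCl)c1`, in a functional assay on HeLa cells (Homo sapiens) for cytotoxicity, read by MTT assay, with a stated time of 48 h (a lower number here means a stronger inhibitor, a higher number a weaker inhibitor), compound 1 gives 1550 nM
compound 2, `C#CCNC(=O)Nc1cccc(CNCc2ccccc2)c1`, in this assay compound 2 gives "not active" (no number reported), with no number

Of the compounds shown here, two have been tested, and they show opposite pictures. Compound 1 carries a chloromethyl group on the shared core and in this assay compound 1 gives 1550 nM. Compound 2 replaces that group with a benzylamine arm and in this assay compound 2 gives "not active" (no number reported), so no number stands for it; its position among the values shown is therefore that of a compound with a result but without a concentration, and nothing more can be read from the pair beyond that compound 1 has a number and compound 2 has none.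

Compound 3, `C#CCNC(=O)Nc1cccc(CNCc2ccc(OC)cc2)c1`, is the next step from compound 2: methoxy in place of hydrogen on an aromatic carbon. Among the measured compounds shown here, no step between measured compounds resembles this change, so in this assay the expectation is no step beyond the scatter, with compound 3 most likely remaining without a number. Compound 3 is estimated to give 30000 nM, in the range 5000 nM to 150000 nM.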

Compound 3, half-maximal inhibitory concentration: 392000 nM
Estimate against measurement, compound 3: 13-fold (1.12 log units) below; the whole stated range lies below it.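

Compound 2 stands without a number in this assay, while compound 3 gives 392000 nM, so no step can be read between the two. The compounds shown leave open whether methoxy in place of hydrogen on the benzyl arm changes the value at all. Nothing shown bears on the reason for this result.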